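Naphthyl-phenyl-pyridines: one assay, two points, one open

A few compounds are considered here, and "the series" means these few. Any claim that something is new, unique, unknown or untested is made for them only; others in the source may bear on it.

Measured so far:
compound 1 `COc1ccc2cc(-c3cccc(-c4ccncc4)c3)ccc2c1` — 4%
compound 2 `Oc1ccc2cc(-c3cccc(-c4cccnc4)c3)ccc2c1` — 0%

Both numbers come from an assay for inhibition of steroid 17-alpha-hydroxylase/17,20 lyase (Homo sapiens), tested at 0.2 uM; a lower number here means a weaker effect, a higher number a stronger effect of the compound at the concentration tested. Compound 1 gives 4% and compound 2 gives 0%. Within the data shown here, compound 2 stands lowest of the two numbers, and its nearest neighbour is compound 1; the gap between them lies within the usual scatter, so the two values show no separation and neither compound can be called weaker or stronger than the other. Among the measured compounds shown here, no step between measured compounds that differ in one place is available in this set.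

The open compound is compound 3 `Oc1ccc2cc(-c3cccc(-c4ccncc4)c3)ccc2c1`. Relative to compound 2 the change is pyridin-4-yl in place of pyridin-3-yl on an aromatic carbon. Since compound 1, which carries pyridin-4-yl, gives 4%, a low reading is expected for compound 3 as well. The step of a number 3 percentage points higher from compound 2 to compound 3 (within the scatter) is expected to be none beyond the scatter, in no clear direction. For compound 3 the estimate in this assay is 3%, with a range from 0% to 12%.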

Compound 3, a percentage reported as inhibition, at one concentration (the size of the read-out at that concentration, not a potency): 31%
The estimate for compound 3 lay 28 percentage points below the measured number; the measured number lies above the stated range.
By their numbers in this assay, from the lowest: compounds 2 and 1 (each within the scatter of the next); then compound 3.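

In this assay the attachment of the pyridine on this aromatic carbon is not neutral: with a free hydroxyl on the shared core, pyridin-4-yl in place of pyridin-3-yl gives a number 31 percentage points higher from compound 2 to compound 3 (beyond the scatter) even though the two compounds have the same atoms, joined differently. Hydrogen in place of methyl on the oxygen gives a number 27 percentage points higher from compound 1 to compound 3 (beyond the scatter) so pyridin-4-yl alone does not bring the higher reading, and among these three compounds it appears only where pyridin-4-yl and the free hydroxyl occur together. Nothing available here gives a reason for either step.

Open, from the compounds shown here alone, is whether the two changes depend on each other, which would take the methyl ether paired with pyridin-3-yl, and whether the nitrogen position matters as much with other groups on that oxygen, such as an ethyl chain. Also open, going by these compounds, is whether an amine or a carboxylic acid in place of the hydroxyl keeps the reading, and how the reading of compound 3 translates into potency, since a single concentration does not give one.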